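This account rests on a few compounds, and the source may have more. Where it says the series, first, only, none or still open, it means among the compounds named here.

Compound 1 `CCC(C)n1ncn(-c2ccc(N3CCN(c4ccc(OC[C@@H]5CO[C@@](CN6CCNCC6)(c6ccc(Cl)cc6Cl)O5)cc4)CC3)cc2)c1=O` gives 608 nM
Compound 2 `CCC(C)n1ncn(-c2ccc(N3CCN(c4ccc(OC[C@@H]5CO[C@@](Cn6nc(C)nc6C)(c6ccc(Cl)cc6Cl)O5)cc4)CC3)cc2)c1=O` gives 221 nM
Compound 3 `CCC(C)n1ncn(-c2ccc(N3CCN(c4ccc(OC[C@@H]5CO[C@@](Cn6cnc(C)c6)(c6ccc(Cl)cc6Cl)O5)cc4)CC3)cc2)c1=O` gives 102 nM

These three compounds share a core and differ only in the group on a saturated chain carbon bound to a saturated ring carbon. In a functional assay on HUVEC cells (Homo sapiens), read by scintillation counting and thymidine incorporation, with a stated time of 24 h (a lower number here means a stronger inhibitor, a higher number a weaker inhibitor), compound 3 has the lowest of the three numbers, and its steps to both others lie beyond the scatter, so it is the strongest inhibitor of the set.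

The next compound, compound 4 `CCC(C)n1ncn(-c2ccc(N3CCN(c4ccc(OC[C@@H]5CO[C@@](Cn6c(C)cnc6C)(c6ccc(Cl)cc6Cl)O5)cc4)CC3)cc2)c1=O`, has 2,5-dimethyl-1H-imidazol-1-yl in place of 4-methyl-1H-imidazol-1-yl at that same place (2,5-dimethyl-1H-imidazol-1-yl in place of 4-methyl-1H-imidazol-1-yl on a saturated chain carbon bound to a saturated ring carbon). The measured steps that bear on this change are the other swaps of this group. Replacing piperazin-1-yl gave a 2.8-fold lower number from compound 1 to compound 2 (0.44 log units; beyond the scatter) and a 6.0-fold lower number from compound 1 to compound 3 (0.78 log units; beyond the scatter), while exchanging the two newer groups gave a 2.2-fold lower number from compound 2 to compound 3 (0.34 log units; beyond the scatter). All three are modest, so a large step in this assay seems unlikely. Going by the values given here, compound 2, the only measured compound with a dimethyl group here, gives 221 nM, which suggests a small rise rather than a fall. The expected change is a 1.5-fold higher number from compound 3 to compound 4 (0.17 log units; within the scatter), a small weakening at most.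

For compound 4 the estimated value is 150 nM, with an expected range from 60 nM to 380 nM.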

Compound 4, half-maximal inhibitory concentration: 765 nM
Compound 4: middle estimate off by 5.1-fold (0.71 log units), on the low side, outside the stated range (above it).
By their numbers in this assay, from the lowest: compound 3; then compound 2; then compounds 1 and 4 (each within the scatter of the next).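

In this assay, a 7.5-fold higher number from compound 3 to compound 4 (0.88 log units; beyond the scatter) shows that this place does not treat all small aromatic rings alike: 2,5-dimethyl-1H-imidazol-1-yl has only one more heavy atom than 4-methyl-1H-imidazol-1-yl and the same count of hydrogen-bond acceptors, yet this swap moves the number further than any earlier swap did. A dimethyl-substituted ring is also no assurance of a good number, since the change from the triazole of compound 2 gives a 3.5-fold higher number from compound 2 to compound 4 (0.54 log units; beyond the scatter), while a 1.3-fold higher number from compound 1 to compound 4 (0.10 log units; within the scatter) means that compound 4 cannot be told apart from compound 1, so the gain seen with the other two rings over piperazin-1-yl is absent here. Nothing in the data shown gives a cause for this loss.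

The compounds shown leave open whether the loss depends on where the methyl groups sit or on how many there are, a question that the plain 1H-imidazol-1-yl and 2-methyl-1H-imidazol-1-yl groups at this place would help to settle. As far as these compounds go, whether this order of groups would hold on a different core also remains open.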